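The source may report more compounds than this note shows. Statements on the series, on what has been measured and on what is new or still open speak of the compounds shown alone.

Compound 1 `Cc1cn(C2CC(N=[N+]=[N-])C(COC(=O)OCCCCCCCCO)O2)c(=O)[nH]c1=O`: > 50000 nM
Compound 2 `Cc1cn(C2CC(N=[N+]=[N-])C(COC(=O)CCCN)O2)c(=O)[nH]c1=O`: > 50000 nM

In a functional assay on MT4 cells (Homo sapiens) for cytotoxicity (a higher number here means that more compound is tolerated, a lower number that less compound is tolerated), compound 1 gives > 50000 nM, which is a limit of the assay rather than a measured number. Compound 2 gives > 50000 nM in this assay, again a limit. Both results sit at the limit of > 50000 nM in this assay, at which 2 of the 2 values shown sit, so the step that the two limits leave unreadable from compound 1 to compound 2 has no readable size. Compound 3 `Cc1cn(C2CC(N=[N+]=[N-])C(COC(=O)OCCCC(=O)O)O2)c(=O)[nH]c1=O` differs from compound 1 by carboxy in place of 5-hydroxypentyl on a saturated chain carbon, three bonds along the chain from an oxygen next to a carbonyl group. Within the data shown here, the only measured step alters the same end of the molecule, but because its two values rest on the limit of > 50000 nM in this assay, at which 2 of the 2 values shown sit, it offers no size to carry over, and no direction can be set for the change in this assay. Because both measured values sit at the limit of > 50000 nM in this assay, at which 2 of the 2 values shown sit, compound 3 is expected to remain at that limit too, an estimated step of a number no higher from compound 1 to compound 3 (the limit leaves the size open). The estimate for compound 3 is 50000 nM, expected to lie between 30000 nM and 100000 nM.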

Compound 3, half-maximal cytotoxic concentration: > 50000 nM
Compound 3: no number, only a limit (the forecaster's own chance of this, stated with the estimate: 85%); the middle value sits exactly at the limit.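

Compound 3 also gives only a limit in this assay, not a number. No step among compound 1, compound 2 and compound 3 can therefore be read: the limit of > 50000 nM in this assay, at which 3 of the 3 values shown sit.

These compounds leave open what concentration would harm the cells, and whether swapping these groups changes it at all.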